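Furan in Place of Chlorophenyl: Expected Cytotoxicity

A few compounds are considered here, and "the series" means these few. Any claim that something is new, unique, unknown or untested is made for them only; others in the source may bear on it.

Compound 1 `CCCc1n[nH]c2c(=O)n(NC(=O)c3ccncc3)c(-c3cccc(OC)c3)nc12`: 0.07% in a functional assay on HT-29 cells (Homo sapiens) for cytotoxicity, read by sulforhodamine B assay, with a stated time of 2 days, tested at 100 uM; a lower number here means less inhibition, a higher number more inhibition at the concentration tested (going by the name of the read-out)
Compound 2 `O=C(Nn1c(-c2cccc([N+](=O)[O-])c2)nc2c(-c3ccc(Cl)cc3)n[nH]c2c1=O)c1cccnc1`: 15.1%
Compound 3 `COc1cccc(-c2nc3c(-c4ccc(C5CCNCC5)cc4)n[nH]c3c(=O)n2NC(=O)c2ccncc2)c1`: 28.1%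

Among these three, compound 2 stands second highest, beyond the scatter from both others: compound 3 sits higher and compound 1 lower. Compound 4 `O=C(Nn1c(-c2cccc([N+](=O)[O-])c2)nc2c(-c3ccco3)n[nH]c2c1=O)c1cccnc1` differs from compound 2 by furan-2-yl in place of 4-chlorophenyl on an aromatic carbon. Among the measured compounds shown here, only one measured step alters the same position: a number 28 percentage points higher from compound 1 to compound 3 (beyond the scatter), where propyl gave way to an aromatic ring and inhibition rose. For the measured compounds named here, no measured step trades one aromatic ring for another at this position, so the footing is thin. Compound 4 is therefore expected to show at most a small decrease, a number 5.1 percentage points lower from compound 2 to compound 4 (within the scatter), giving an estimated 10%, within a range from 0% to 25%.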

Compound 4, a percentage reported as inhibition, at one concentration (the size of the read-out at that concentration, not a potency): 11.7%
Estimate against measurement, compound 4: 1.7 percentage points below, and the stated range covers the measured number.
By their numbers in this assay, from the lowest: compound 1; then compounds 4 and 2 (each within the scatter of the next); then compound 3.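

Swapping one aromatic ring for another on this aromatic carbon gives, in this assay, a number 3.4 percentage points lower from compound 2 to compound 4 (within the scatter). So at this position, 4-chlorophenyl and furan-2-yl cannot be told apart in this read-out, even though the entering ring is five-membered, carries an oxygen and has no chlorine. Nothing available accounts for this result.

Still open, going by these compounds, is whether a thiophene ring on this carbon would read the same, or whether a carboxylic acid on the 4-chlorophenyl ring in place of chlorine would move the number beyond the scatter.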